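This account rests on a few compounds, and the source may have more. Where it says the series, first, only, none or still open, it means among the compounds named here.

Compound 1 `CN(C)c1ccc(-c2cc(C(=O)N3CCC4(CC3)CC(=O)c3nn(C(C)(C)C)cc3O4)c3ccccc3n2)cc1`: > 10000 nM
Compound 2 `CC(C)(C)n1cc2c(n1)C(=O)CC1(CCN(C(=O)c3cc(-c4ccccn4)nc4ccccc34)CC1)O2`: 8100 nM

Among the compounds with values here, in a functional assay on MDA-MB-231 cells (Homo sapiens) for inhibition, read by MTT assay, with a stated time of 72 h (a higher number here means a weaker inhibitor, a lower number a stronger inhibitor), compound 2 gives 8100 nM, the only actual number available for this series. Compound 1 reads > 10000 nM, which is a limit of the assay and not a number. The other measurement therefore offers only (the limit of > 10000 nM in this assay, at which 1 of the 2 values shown sits).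

The next compound, compound 3 `CC(C)(C)n1cc2c(n1)C(=O)CC1(CCN(C(=O)c3cc(-c4ccncc4)nc4ccccc34)CC1)O2`, has the same atoms as compound 2 joined differently, with pyridin-4-yl in place of pyridin-2-yl on an aromatic carbon.

Within the data shown here, only one measured step bears on this carbon: an at least 1.2-fold lower number from compound 1 to compound 2 (0.09 log units; that floor lies within the scatter). That step exchanged 4-(dimethylamino)phenyl for pyridin-2-yl, so it says little about moving between two pyridinyl groups. No measurement compares pyridin-2-yl with pyridin-4-yl directly. With compound 2 at 8100 nM as the anchor, no change beyond the scatter is expected in this assay, in either direction. The expected step is a 1.2-fold lower number from compound 2 to compound 3 (0.06 log units; within the scatter). For compound 3 the estimated value is 7000 nM, with an expected range from 2500 nM to 10000 nM.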

Compound 3, half-maximal inhibitory concentration: 1650 nM
Compound 3: the middle estimate sits 4.2-fold (0.63 log units) above what was measured, and the stated range ends above it.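

In this assay, the change of pyridin-2-yl to pyridin-4-yl keeps the same atoms and gives a 4.9-fold lower number from compound 2 to compound 3 (0.69 log units; beyond the scatter), so where the ring nitrogen lies in this group makes a difference beyond the scatter, which the earlier step at this carbon, within the scatter, could not show. Within the data shown here, the exchange of 4-(dimethylamino)phenyl for pyridin-4-yl gives an at least 6.0-fold lower number from compound 1 to compound 3 (0.78 log units; beyond the scatter), the first step from that group at this carbon that clears the scatter. Compound 1 stands at a limit of the assay and not a number, so that step is only a floor: the limit of > 10000 nM in this assay, at which 1 of the 3 values shown sits.

As far as these compounds go, it remains open whether pyridin-3-yl at this carbon, an unsubstituted phenyl or a saturated ring amine such as piperidin-4-yl would read closer to compound 2 or to compound 3 in this assay. The compounds shown also vary only this one carbon, so they say nothing about how the tert-butyl group or the carbonyl of the shared core bears on the value of compound 3, 1650 nM.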